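The source may report more compounds than this note shows. Statements on the series, on what has been measured and on what is new or still open speak of the compounds shown alone.

Measured in a functional assay on MGC-803 cells (Homo sapiens) for inhibition, read by sulforhodamine B assay; a higher number here means a weaker inhibitor, a lower number a stronger inhibitor:
- compound 1 `O=C1C(Nc2ccc(Br)cc2)=CC(=O)c2c1nc1n2[C@H]2OC[C@@H](O)[C@H]2OC1`: 2020 nM
- compound 2 `COc1ccc(NC2=CC(=O)c3c(nc4n3[C@H]3OC[C@@H](O)[C@H]3OC4)C2=O)cc1`: 2150 nM

Within the data shown here, compound 2, at 2150 nM, cannot be told apart from compound 1, the only other compound measured. Among the measured compounds shown here, the single measured step is a 1.1-fold higher number from compound 1 to compound 2 (0.03 log units; within the scatter), with methoxy in place of bromo on an aromatic carbon.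

Compound 3 `O=C1C(NC2CC2)=CC(=O)c2c1nc1n2[C@H]2OC[C@@H](O)[C@H]2OC1` makes a larger change: cyclopropyl in place of 4-methoxyphenyl on an amine nitrogen. In words, cyclopropyl replaces 4-methoxyphenyl on an amine nitrogen, so the aromatic ring itself leaves. For the measured compounds named here, the step from compound 1 to compound 2 kept that ring, and no measured compound lacks it, so that step offers only weak guidance. A modest move towards a higher number in this assay is expected, with wide uncertainty in either direction. The expected size of the change is a 1.4-fold higher number from compound 2 to compound 3 (0.14 log units; within the scatter). Compound 3 is estimated at 3000 nM, within an expected range of 900 nM to 10000 nM.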

Compound 3, half-maximal inhibitory concentration: > 4000 nM
Compound 3: only a limit was reported; the forecaster's own chance of this, stated with the estimate: 8%; middle value at least 1.3-fold (0.12 log units) away from the limit.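

In this assay compound 3 is reported only as a limit, not as a number: the limit of > 4000 nM in this assay, at which 1 of the 3 values shown sits. Cyclopropyl on the amine nitrogen gives an at least 1.8-fold higher number from compound 2 to compound 3 (0.26 log units; that floor lies within the scatter), and the comparison with the 4-bromophenyl group gives an at least 1.9-fold higher number from compound 1 to compound 3 (0.29 log units; that floor lies within the scatter). Swapping methoxy for bromo had only tested a substituent on the aromatic ring, whereas this change removes the ring and shows no gain in strength, although both floors lie within the scatter and so a real loss is possible but not established.

The compounds shown leave open how far the true value of compound 3 lies from its limit. They also leave open whether the aromatic ring itself matters or only the size of the group, which a benzyl group, a piperidine or a straight butyl chain on this nitrogen could help to separate.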